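Methoxy in place of fluoro: working notes on compound 3

The source may report more compounds than this note shows. Statements on the series, on what has been measured and on what is new or still open speak of the compounds shown alone.

Measured so far in a functional assay on J774 cells (Mus musculus) for cytotoxicity, read by resazurin assay (on this read-out lower numbers stand for stronger inhibition and higher numbers for weaker inhibition), as follows
compound 1 (`OCCCCCC(O)c1ccc(-c2ccc(F)cc2)cc1`) gives 18000 nM 
compound 2 (`OCCCCCC(O)c1ccc(-c2ccc(F)cc2F)cc1`) gives 8000 nM 

Among the compounds with values here, compound 2 holds the lower of the two numbers, and compound 1 is its only measured neighbour. Within the data shown here, the one measured step is a 2.3-fold lower number from compound 1 to compound 2 (0.35 log units; beyond the scatter) and came with fluoro in place of hydrogen on an aromatic carbon. It is modest but beyond the scatter.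

Compound 3 (`COc1cc(F)ccc1-c1ccc(C(O)CCCCCO)cc1`) has methoxy in place of fluoro on an aromatic carbon, on a six-membered aromatic ring of carbon only, ortho to a large group and meta to a fluoro group. Among the measured compounds shown here, this is the carbon that changed in the measured step, so that step is the only guide. For the measured compounds named here, no measured compound carries methoxy, so it bounds the likely size only loosely. A change no larger than modest is expected, leaning slightly towards a higher number. The expected step is a 1.4-fold higher number from compound 2 to compound 3 (0.14 log units; within the scatter) and so is not clearly beyond the scatter. The estimated value for compound 3 is 11000 nM with an expected range from 5000 nM to 25000 nM in this series.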

Compound 3, half-maximal inhibitory concentration: 70000 nM
The estimate for compound 3 lay 6.4-fold (0.80 log units) below the measured number; the measured number lies above the stated range.
By their numbers in this assay, from the lowest: compound 2; then compound 1; then compound 3.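

In this assay, the step of an 8.8-fold higher number from compound 2 to compound 3 (0.94 log units; beyond the scatter) shows that the group on this aromatic carbon, ortho to a large group and meta to a fluoro group, can move the number upward as well as downward. Measured against hydrogen on the same carbon, methoxy gives a 3.9-fold higher number from compound 1 to compound 3 (0.59 log units; beyond the scatter) and so runs opposite to the earlier step of a 2.3-fold lower number from compound 1 to compound 2 (0.35 log units; beyond the scatter) for fluoro in place of hydrogen. Substitution at this carbon therefore does not lower the number as such: the direction depends on the group that enters, with the hydrogen compound, compound 1, lying between the fluoro compound, compound 2, and the methoxy compound, compound 3. No supporting data bear on what lies behind this reversal.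

Hydrogen, fluoro and methoxy on one carbon leave open whether the rise follows the oxygen of methoxy or its added carbon, and a hydroxy, a chloro or an ethoxy group at this carbon would help separate these readings. From the compounds shown here alone, it also remains open whether the same order of groups holds on other aromatic carbons of the shared core, or when the fluoro group is replaced by a chloro group.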